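The source may report more compounds than this note shows. Statements on the series, on what has been measured and on what is new or still open speak of the compounds shown alone.

Measured compounds
compound 1 `CC(C)(C)c1csc(N)c1C(=O)c1ccc(Cl)cc1` — 1%
compound 2 `CC(C)(C)Cc1csc(N)c1C(=O)c1ccc(Cl)cc1` — 1%
compound 3 `Cc1ccc(C(=O)c2c(CC(C)(C)C)csc2N)cc1` — 1%

In an assay on CHO cells for displacement of a labelled ligand from adenosine receptor A1 (Homo sapiens), read by scintillation counting, tested at 10 uM (a lower number here means less inhibition, a higher number more inhibition at the concentration tested (going by the name of the read-out)), compound 1 gives 1%, compound 2 gives 1% and compound 3 gives 1%. Compound 2 stands level with both neighbours at the digits shown: the step of no change at the digits printed from compound 1 to compound 2 (within the scatter) and the step of no change at the digits printed from compound 2 to compound 3 (within the scatter) both lie within the scatter, so the three measured compounds are indistinguishable here, all at the bottom of the read-out.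

Compound 4 `Cc1noc(C)c1-c1sc(N)c(C(=O)c2ccc(Cl)cc2)c1CC(C)(C)C` differs from compound 2 by 3,5-dimethyl-1,2-oxazol-4-yl in place of hydrogen on an aromatic carbon. Neither measured step bears directly on this change. The step from compound 1 to compound 2 swapped neopentyl for tert-butyl, the step from compound 2 to compound 3 swapped methyl for chloro, and both left the read-out unchanged within the scatter. Among the compounds with values here, no measured compound carries a ring at the place where the new group enters, so the series gives no precedent for it, and nothing measured so far has moved the read-out at all.

The expectation for compound 4 is therefore a step of a number 2 percentage points higher from compound 2 to compound 4 (within the scatter), that is, no change beyond the scatter. Compound 4 is estimated at 3%, within a range from 0% to 15%.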

Compound 4, a percentage reported as inhibition, at one concentration (the size of the read-out at that concentration, not a potency): 1%
Compound 4: the middle estimate sits 2 percentage points above what was measured; the range from low to high includes it.
By their numbers in this assay, from the lowest: compounds 1, 2, 3 and 4 (each within the scatter of the next).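

In this assay, within the data shown here, placing 3,5-dimethyl-1,2-oxazol-4-yl on the aromatic carbon next to the ring sulfur gives no change at the digits printed from compound 2 to compound 4 (within the scatter), the first evidence on a change at this position rather than at the neopentyl or tert-butyl group or the para-free description of the aryl substituent.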